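The source may report more compounds than this note shows. Statements on the series, on what has been measured and on what is new or still open speak of the compounds shown alone.

Measured so far:
compound 1, `COc1ccc(-c2cc(N3CCC(CNS(N)(=O)=O)CC3)ncn2)cc1` — > 100000 nM
compound 2, `NS(=O)(=O)NCC1CCN(c2cc(-c3cccc(Cl)c3)ncn2)CC1` — 47500 nM

Compound 1, `COc1ccc(-c2cc(N3CCC(CNS(N)(=O)=O)CC3)ncn2)cc1`, reaches only a limit of the assay in a functional assay on HT-29 cells (Homo sapiens) for antiproliferative activity, read by sulforhodamine B assay, with a stated time of 48 h (a lower number here means a stronger inhibitor of growth, a higher number a weaker inhibitor of growth), where it reads > 100000 nM; that is not a number. Compound 2, `NS(=O)(=O)NCC1CCN(c2cc(-c3cccc(Cl)c3)ncn2)CC1`, gives 47500 nM in this assay. So compound 2 holds the only actual number shown, the other value being the limit (the limit of > 100000 nM in this assay, at which 1 of the 2 values shown sits). Among the measured compounds shown here, the single measured step is an at least 2.1-fold lower number from compound 1 to compound 2 (0.32 log units; beyond the scatter), and it can only be given as a lower bound because compound 1 sits at the limit of > 100000 nM in this assay, at which 1 of the 2 values shown sits.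

Compound 3, `NS(=O)(=O)NCC1CCN(c2cc(-c3ccccc3F)ncn2)CC1`, differs from compound 2 by 2-fluorophenyl in place of 3-chlorophenyl on an aromatic carbon. The measured step of an at least 2.1-fold lower number from compound 1 to compound 2 (0.32 log units; beyond the scatter) changed a different group at the same place and is open-ended, so it offers little direct guidance; it shows only that this site can move the number at least modestly. For the measured compounds named here, no step yet compares one substituted phenyl with another. Compound 3 is therefore expected to land close to compound 2, perhaps somewhat weaker, a step of a 1.5-fold higher number from compound 2 to compound 3 (0.17 log units; within the scatter). Compound 3 is estimated at 70000 nM, within a range from 25000 nM to 150000 nM.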

Compound 3, concentration for 50% growth inhibition: 80400 nM
Beside the measured number, compound 3's estimate is 1.1-fold (0.06 log units) below it; low and high end bracket the measured number.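

In this assay, among the compounds shown here, the step of a 1.7-fold higher number from compound 2 to compound 3 (0.23 log units; within the scatter) is the first with a real number at both ends, and the first to compare one halogen-bearing phenyl with another. Swapping 3-chlorophenyl for 2-fluorophenyl on this aromatic carbon gives two compounds that cannot be told apart, so this change does not show that either group is the better one. The other new step, an at least 1.2-fold lower number from compound 1 to compound 3 (0.09 log units; that floor lies within the scatter), does not separate 2-fluorophenyl from 4-methoxyphenyl, and it can be read only as a floor because compound 1 stands at a limit of the assay: the limit of > 100000 nM in this assay, at which 1 of the 3 values shown sits.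

The swap from compound 2 to compound 3 changes both the halogen and its place on the phenyl ring, so the compounds shown cannot tell these two changes apart, and a 3-fluorophenyl or a 2-chlorophenyl would be needed to do so. On these data alone, it also remains open whether a phenyl carrying an amine or a carboxylic acid, or a group other than a substituted phenyl at this carbon, would give a clearly lower number than these.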